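Swapping a Carbonate for an Ester at One Carbonyl

This account rests on a few compounds, and the source may have more. Where it says the series, first, only, none or still open, it means among the compounds named here.

Measured so far:
compound 1, `Nc1ncnc2c1nc(NCc1ccc(-c3ccccc3)cc1)n2[C@@H]1O[C@H](CO)[C@@H](O)[C@H]1O`, gives 640 nM in an assay on COS-7 cells for inhibition of sodium/nucleoside cotransporter 2 (Homo sapiens), read by scintillation counting, in the presence of a further agent that is not named here; on this read-out lower numbers stand for stronger inhibition and higher numbers for weaker inhibition.
compound 2, `CCCCCOC(=O)OC[C@H]1O[C@@H](n2cnc3c(N)ncnc32)[C@H](O)[C@@H]1O`, gives only a limit, > 100000 nM, in this assay.

Compound 2 therefore has no true number: its result is a limit of the assay, (the limit of > 100000 nM in this assay, at which 1 of the 2 values shown sits). Going by the values given here, compound 1 sits inside the measurable range, so of this pair one can say only that compound 2 reaches the limit while compound 1 does not.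

Compound 3, `CCCCCC(=O)OC[C@H]1O[C@@H](n2cnc3c(N)ncnc32)[C@H](O)[C@@H]1O`, keeps the core of compound 2 and differs in one place: pentyl in place of pentyloxy on a carbonyl carbon. Among the compounds with values here, no measured pair of compounds shows what such a swap does in this assay, so the expectation rests on compound 2 alone. The expected step, a number no higher from compound 2 to compound 3 (the limit leaves the size open), is none beyond the scatter. Compound 3 is thus estimated at 100000 nM in this assay, within a range from 30000 nM to 300000 nM, and it is expected that the assay may again report only a limit.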

Compound 3, half-maximal inhibitory concentration: > 100000 nM
Compound 3 was reported as a limit (the forecaster's own chance of this, stated with the estimate: 70%); the middle value lies on the limit itself.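

Going by these compounds alone, compound 2 and compound 3 both end at a limit of the assay rather than at a true number, so no step between them can be read: the limit of > 100000 nM in this assay, at which 2 of the 3 values shown sit. From the compounds shown here alone, what stays open is whether pentyl in place of pentyloxy changes anything in this assay.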